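The source may report more compounds than this note shows. Statements on the series, on what has been measured and on what is new or still open speak of the compounds shown alone.

Values in a functional assay (mast cells) for inhibition, with Rattus norvegicus as the target (a lower number here means that less compound is needed, a higher number that more compound is needed for the effect), so far:
Compound 1 `CC1CC/C(=N\Nc2ccc(O)cc2)c2ncc(C(=O)O)c(=O)n21`: 1300 nM
Compound 2 `CC1CC/C(=N\Nc2ccc(C3CC3)cc2)c2ncc(C(=O)O)c(=O)n21`: 1000 nM

Going by the values given here, only two numbers are known, and compound 2 cannot be separated from the other measured compound. Cyclopropyl in place of hydroxy on an aromatic carbon gives a 1.3-fold lower number from compound 1 to compound 2 (0.11 log units; within the scatter).

The next change leads to compound 3 `CNC(=O)c1ccc(N/N=C2\CCC(C)n3c2ncc(C(=O)O)c3=O)cc1`, which carries methylcarbamoyl in place of cyclopropyl on an aromatic carbon, para to a large group: methylcarbamoyl in place of cyclopropyl on an aromatic carbon.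

Among the compounds with values here, only one measured step bears on this change, as it concerns the same place on the molecule. Methylcarbamoyl itself has not been measured on the shared core, so no step speaks for it directly, and a single pair is a thin guide. Within the data shown here, with a 1.3-fold lower number from compound 1 to compound 2 (0.11 log units; within the scatter) as the only evidence, no step beyond the scatter is expected in this assay, and neither direction is favoured.

For compound 3 the expected value is 1200 nM, with an estimated range of 350 nM to 4000 nM.

The expected step is a 1.2-fold higher number from compound 2 to compound 3 (0.08 log units; within the scatter).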

Compound 3, half-maximal effective concentration: 100000 nM
Compound 3: middle estimate off by 83-fold (1.92 log units), on the low side; measured number above the stated range.
By their numbers in this assay, from the lowest: compounds 2 and 1 (each within the scatter of the next); then compound 3.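

In this assay, the place on the aromatic ring para to a large group proves far from indifferent: methylcarbamoyl in place of cyclopropyl gives a 100-fold higher number from compound 2 to compound 3 (2.00 log units; beyond the scatter) and methylcarbamoyl in place of hydroxy gives a 77-fold higher number from compound 1 to compound 3 (1.89 log units; beyond the scatter) in the same direction. Hydroxy and cyclopropyl had stayed within the scatter of each other and gave no sign that this place could separate one substituent from another, yet methylcarbamoyl stands well apart from both, so a change here can matter greatly. Nothing measured beyond these numbers accounts for the large step, and which feature of methylcarbamoyl lies behind it remains unknown.

The compounds shown leave open whether the step belongs to the amide as a whole or to its methyl, a question that the unsubstituted carbamoyl or dimethylcarbamoyl on the same carbon would address. They also leave open how a carboxylic acid, an amine or a methoxy group at this place would compare with hydroxy and cyclopropyl on the one hand and methylcarbamoyl on the other.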